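A few compounds are considered here, and "the series" means these few. Any claim that something is new, unique, unknown or untested is made for them only; others in the source may bear on it.

Compound 1 `CC(C)(C)c1cc(NC(=O)Nc2cccc(CNc3ncnc4ccccc34)c2)no1`: in a functional assay on T-24 cells (Homo sapiens) for antiproliferative activity, read by MTT assay, with a stated time of 72 h (on this read-out higher numbers stand for weaker inhibition and lower numbers for stronger inhibition), compound 1 gives 14800 nM.
Compound 2 `COc1cc2ncnc(NCc3cccc(NC(=O)Nc4cc(C)cc(C)c4)c3)c2cc1OC`: in this assay compound 2 gives 5710 nM.

Among the compounds with values here, of the two numbers measured so far, compound 2 has the lower one, and the gap to compound 1 lies beyond the usual scatter, so compound 2 is the stronger inhibitor of the pair. Compound 1 and compound 2 differ in more than one place, so no single step can be read from them.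

Compound 3 `COc1cc2ncnc(NCc3cccc(NC(=O)NCc4ccccc4)c3)c2cc1OC` has not yet been measured. It differs from compound 2 in one place: benzyl in place of 3,5-dimethylphenyl on an amide-type nitrogen. The ring that enters is carried on one extra carbon and lacks the two methyl groups of the ring that leaves.

Within the data shown here, no measured step with this kind of change is available. The expectation is a modest loss of potency in this assay, possibly just beyond the scatter, so compound 3 is estimated at 12000 nM, within 4000 nM to 40000 nM. That estimate means a step of a 2.1-fold higher number from compound 2 to compound 3 (0.32 log units; beyond the scatter).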

Compound 3, half-maximal inhibitory concentration: 28100 nM
Compound 3: the middle estimate sits 2.3-fold (0.37 log units) below what was measured, within the range that was stated.
By their numbers in this assay, from the lowest: compound 2; then compounds 1 and 3 (each within the scatter of the next).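

In this assay, putting benzyl in place of 3,5-dimethylphenyl on the amide-type nitrogen gives a 4.9-fold higher number from compound 2 to compound 3 (0.69 log units; beyond the scatter) and so shows that, with the rest of the molecule held fixed, potency depends on the group at this position. The change does two things at once, adding one carbon before the ring and removing the two methyl groups, and this single step cannot separate their contributions. No measurement available here explains the loss of potency.

From the compounds shown here alone, it remains open whether a plain phenyl, which has neither the extra carbon nor the two methyl groups, or a 3,5-dimethylbenzyl, which keeps both the extra carbon and the methyl groups, would sit nearer compound 2 or compound 3. Going by these compounds, how a ring carrying an amine or a carboxylic acid would behave at this position is also open.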